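Ring stereocentres and maximal response in this series

A few compounds are considered here, and "the series" means these few. Any claim that something is new, unique, unknown or untested is made for them only; others in the source may bear on it.

Measured so far, in an assay on HEK293 cells for agonist activity at putative P2Y purinoceptor 10 (Mus musculus), with a stated time of 1 h; on this read-out higher numbers stand for larger maximal responses and lower numbers for smaller maximal responses:
- compound 1 `CCCCCCCCCCCOc1ccccc1CCC(=O)O[C@H]1CCOC[C@H]1OP(=O)(O)OC[C@H](N)C(=O)O`: 3.2%
- compound 2 `CCCCCCCCCCCOc1ccccc1CCC(=O)O[C@@H]1CCOC[C@H]1OP(=O)(O)OC[C@H](N)C(=O)O`: 10.6%

Compounds 1 and 2 share all atoms and bonds and differ only in how one saturated ring carbon is drawn. In this assay compound 1 gives 3.2% and compound 2 gives 10.6%. The step of a number 7.4 percentage points higher from compound 1 to compound 2 (within the scatter) lies within the scatter, and the only structural fact attached to it is the fact that one of compounds 1 and 2 is drawn with a defined configuration and the other without, at the place where they differ. On the numbers shown compound 2 stands highest of the two, but its gap to compound 1 is within the scatter, so no order between them can be read.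

Compound 3 `CCCCCCCCCCCOc1ccccc1CCC(=O)O[C@H]1CCOC[C@@H]1OP(=O)(O)OC[C@H](N)C(=O)O` is not yet measured. Its change from compound 2 is the two compounds have the same atoms and bonds; at least one stereo element is drawn with a configuration in one of them and without one in the other: 2 of 4 stereo elements differ; a stereocentre at a saturated ring carbon is drawn R in compound 2 and S in compound 3; a stereocentre at a saturated ring carbon is drawn R in compound 2 and S in compound 3, that is, both saturated ring carbons are redrawn, while the remaining two stereo elements stay as in compound 2.

Going by the values given here, the only measured step that bears on this change is the single ring-carbon inversion from compound 1 to compound 2, which stayed within the scatter at a low level of response. Nothing measured suggests that inverting a second ring carbon moves the number beyond the scatter. Compound 3 is therefore expected to give 6%, in a range from 0% to 20%. The step of a number 4.6 percentage points lower from compound 2 to compound 3 (within the scatter) is expected to remain within the scatter.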

Compound 3, largest response reached (Emax), in percent of the reference or control that the assay uses: 11.1%
The estimate for compound 3 lay 5.1 percentage points below the measured number, within the range that was stated.
By their numbers in this assay, from the lowest: compounds 1, 2 and 3 (each within the scatter of the next).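

In this assay the step of a number 0.5 percentage points higher from compound 2 to compound 3 (within the scatter) shows that redrawing both saturated ring carbons together leaves the number within the scatter, which the single redrawing in the earlier pair could not show. The step of a number 7.9 percentage points higher from compound 1 to compound 3 (within the scatter) is also within the scatter, so the three ring-carbon arrangements shown cannot be placed in any order, and no sensitivity of the maximal response to configuration at these two carbons can be read from them. The only structural fact attached to the double redrawing is this: the fact that one of compounds 2 and 3 is drawn with a defined configuration and the other without, at the place where they differ

What the compounds shown leave open is how the number behaves for the fourth combination of the two ring carbons, and for a redrawing of either of the two remaining stereo elements. Also open, from the compounds shown here alone, is whether a change in the atoms themselves, such as an amide in place of the ester or a longer chain on the ether oxygen, would move the response in this assay beyond the scatter.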